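Carbonyl substituent: amide to fluorobenzyl ester

A few compounds are considered here, and "the series" means these few. Any claim that something is new, unique, unknown or untested is made for them only; others in the source may bear on it.

Measured in an assay on HL-60 cells for agonist activity at vitamin D3 receptor (Homo sapiens), read by microscopy, with a stated time of 96 h; a higher number here means that more compound is needed for the effect, a lower number that less compound is needed:
compound 1 `CCn1c(C(=O)NCC(OC)OC)ccc1C(CC)(CC)c1ccc(OCC(=O)C(C)(C)C)c(C)c1`: 130 nM
compound 2 `C=CCN(C)C(=O)c1ccc(C(CC)(CC)c2ccc(OCC(=O)C(C)(C)C)c(C)c2)n1CC`: 21600 nM
compound 3 `C=CCN(C)C(=O)c1ccc(C(CC)(CC)c2ccc(OCC(O)C(C)(C)C)c(C)c2)n1CC`: 3950 nM

Compound 3 stands second highest of the three numbers; the step of a 5.5-fold lower number from compound 2 to compound 3 (0.74 log units; beyond the scatter) brought it down from compound 2, while compound 1 lies far lower still.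

Compound 4 `CCn1c(C(=O)OCc2ccc(F)cc2)ccc1C(CC)(CC)c1ccc(OCC(O)C(C)(C)C)c(C)c1` differs from compound 3 only at the carbonyl carbon: (4-fluorobenzyl)oxy in place of allyl(methyl)amino on a carbonyl carbon. Going by the values given here, the one step at this position, a 170-fold higher number from compound 1 to compound 2 (2.22 log units; beyond the scatter), was large, so a change on the carbonyl carbon can move this assay by a large margin; the step of a 5.5-fold lower number from compound 2 to compound 3 (0.74 log units; beyond the scatter) concerns a different place and does not bear directly. Among the compounds with values here, no measured pair converts an amide to an ester, so the direction is open; a large step in either direction is possible. The estimate for compound 4 is 1200 nM, range 150 nM to 10000 nM, an expected step of a 3.3-fold lower number from compound 3 to compound 4 (0.52 log units; beyond the scatter).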

Compound 4, half-maximal effective concentration: > 50000 nM
Compound 4 was reported as a limit (the forecaster's own chance of this, stated with the estimate: 5%); middle value at least 41-fold (1.61 log units) away from the limit.
By their numbers in this assay, from the lowest: compound 1; then compound 3; then compound 2. At a limit, above all of these: compound 4.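

In this assay, the first ester at this carbonyl carbon settles the direction for this change: an at least 12-fold higher number from compound 3 to compound 4 (1.10 log units; beyond the scatter). Compound 4 is a limit of the assay, not a number: the limit of > 50000 nM in this assay, at which 1 of the 4 values shown sits.
Alongside a 170-fold higher number from compound 1 to compound 2 (2.22 log units; beyond the scatter), this is a second large upward step on the carbonyl carbon, here with the 1-hydroxy-2,2-dimethylpropyl chain rather than the (tert-butyl)carbonyl chain.

The compounds shown do not separate the ester link from the 4-fluorobenzyl group, which a 4-fluorobenzyl amide would do. From the compounds shown here alone, a free carboxylic acid on the same carbonyl carbon also remains open.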